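Swapping piperazine for piperidine: tolerated concentration in cells

This account rests on a few compounds, and the source may have more. Where it says the series, first, only, none or still open, it means among the compounds named here.

Compound 1 `CN1CCN(CC(=O)N[C@@H]2C[C@H]3CC[C@]2(C)C3(C)C)CC1`: 853000 nM
Compound 2 `CN1CCN(CCC(=O)N[C@@H]2C[C@H]3CC[C@]2(C)C3(C)C)CC1`: 486000 nM
Compound 3 `CC1CCN(CC(=O)N[C@@H]2C[C@H]3CC[C@]2(C)C3(C)C)CC1`: 78000 nM

These three values come from an ADME assay on HEK-293T cells (Homo sapiens) for cytotoxicity, read by MTT assay, with a stated time of 48 h; a higher number here means that more compound is tolerated, a lower number that less compound is tolerated. Compound 1 and compound 3 differ in one place: 4-methylpiperidin-1-yl in place of 4-methylpiperazin-1-yl on a saturated chain carbon bound to a carbonyl carbon. That change produced an 11-fold lower number from compound 1 to compound 3 (1.04 log units; beyond the scatter). Compound 2 differs from compound 1 in the core itself; that difference is not broken down here. Compound 4 `CC1CCN(CCC(=O)N[C@@H]2C[C@H]3CC[C@]2(C)C3(C)C)CC1` is not yet measured. It stands to compound 2 as compound 3 stands to compound 1: 4-methylpiperidin-1-yl in place of 4-methylpiperazin-1-yl on a saturated chain carbon, two bonds along the chain from a carbonyl carbon. The surroundings are not identical, since in the earlier pair the group sits on a saturated chain carbon bound to a carbonyl carbon, while here it sits on a saturated chain carbon, two bonds along the chain from a carbonyl carbon; it is therefore the same kind of change, not the same change. A step of similar size is expected, a 9.7-fold lower number from compound 2 to compound 4 (0.99 log units; beyond the scatter), because the earlier pair gave an 11-fold lower number from compound 1 to compound 3 (1.04 log units; beyond the scatter). Compound 4 is estimated at 50000 nM, likely between 15000 nM and 200000 nM.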

Compound 4, half-maximal cytotoxic concentration: 93600 nM
The estimate for compound 4 lay 1.9-fold (0.27 log units) below the measured number, and the stated range covers the measured number.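

In this assay, putting 4-methylpiperidin-1-yl in place of 4-methylpiperazin-1-yl on the second core again lowers the number, with a 5.2-fold lower number from compound 2 to compound 4 (0.72 log units; beyond the scatter). The change therefore carries over in direction, and its size on the two cores does not differ beyond the scatter: the same change on two cores in this assay, an 11-fold lower number (1.04 log units; beyond the scatter) from compound 1 to compound 3 and a 5.2-fold lower number (0.72 log units; beyond the scatter) from compound 2 to compound 4, 2.1-fold (0.32 log units) apart, within the scatter of two such steps

Within the data shown here, this rests on only two pairs of compounds, so it shows that the change carries between these two cores, but not that it would do so on any other core, and it does not explain why the number falls.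

The compounds shown leave open whether a morpholine or an unsubstituted piperidine in the same place would give a similar step. They also leave open whether the step would hold with a longer chain.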